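The compounds below may be only part of what the source reports. "The series", "measured", "known", "first", "only" and "open" are said of these compounds alone.

In a functional assay on U-373MG ATCC cells (Homo sapiens) for inhibition, read by MTT assay, with a stated time of 72 h (on this read-out lower numbers stand for stronger inhibition of growth and higher numbers for weaker inhibition of growth), compound 1 (`CC1(C)CCC[C@]2(C)[C@@H](C=O)C(/C=C/C(=O)OCc3ccccc3)=CC[C@@H]12`) gives 39000 nM while compound 2 (`COC(=O)/C=C/C=C/C1=CC[C@H]2C(C)(C)CCC[C@]2(C)[C@H]1C=O`) gives 27000 nM and compound 3 (`CC1(C)CCC[C@]2(C)[C@@H](C=O)C(/C=C/C#N)=CC[C@@H]12`) gives 36000 nM as its number. These three numbers lie within the usual scatter of one another, so compound 3 stands level with the other two and no order can be read among them. Compound 4 (`CC(=O)/C=C/C1=CC[C@H]2C(C)(C)CCC[C@]2(C)[C@H]1C=O`) has acetyl in place of cyano on a double-bonded chain carbon bound to a double-bonded chain carbon. Among the measured compounds shown here, one measured step bears on this, because the same place changes in a 1.3-fold higher number from compound 2 to compound 3 (0.12 log units; within the scatter) and that step stayed within the scatter. For the measured compounds named here, it is only a single step, and no measured pair shows acetyl itself. No step beyond the scatter is therefore expected in this assay for this change. The expected step is a 1.2-fold lower number from compound 3 to compound 4 (0.08 log units; within the scatter) and so remains within the scatter. For compound 4 the estimated value is 30000 nM with an expected range from 14000 nM to 60000 nM around it.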

Compound 4, concentration for 50% growth inhibition: 25000 nM
Estimate against measurement, compound 4: 1.2-fold (0.08 log units) above; measured number inside the range.
By their numbers in this assay, from the lowest: compounds 4, 2, 3 and 1 (each within the scatter of the next).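

In this assay, acetyl in place of cyano on a double-bonded chain carbon bound to a double-bonded chain carbon gives a small change (a 1.4-fold lower number from compound 3 to compound 4 (0.16 log units; within the scatter)), so this place now holds a third group without a step beyond the scatter. Among the compounds shown here, the other two comparisons agree: acetyl in place of 2-(methoxycarbonyl)ethenyl at the same place (a 1.1-fold lower number from compound 2 to compound 4 (0.03 log units; within the scatter)) and methyl in place of benzyloxy on a carbonyl carbon (a 1.6-fold lower number from compound 1 to compound 4 (0.19 log units; within the scatter)) also leave compound 4 level with the others, and no compound here goes against this. No outside evidence on these compounds speaks to why the four numbers sit so close.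

As far as these compounds go, what stays open is whether any group at this place can move the number beyond the scatter. An amine or a carboxylic acid there remains an untested kind of group among the compounds shown.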